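This account rests on a few compounds, and the source may have more. Where it says the series, first, only, none or still open, it means among the compounds named here.

Measured compounds in a functional assay on MCF7 cells (Homo sapiens) for cytotoxicity, read by sulforhodamine B assay, with a stated time of 48 h; a lower number here means a stronger inhibitor, a higher number a weaker inhibitor:
compound 1, `CCc1ccccc1OS(=O)(=O)c1ccc(NC(=O)NCCCCl)cc1`, gives 15000 nM
compound 2, `CCCc1ccccc1OS(=O)(=O)c1ccc(NC(=O)NCCCCl)cc1`, gives 15000 nM
compound 3, `CCc1ccccc1NS(=O)(=O)c1cccc(NC(=O)NCCCCl)c1`, gives 43000 nM

Compound 1 and compound 2 share one core and differ only by methyl in place of hydrogen on a saturated chain carbon, two bonds along the chain from an aromatic carbon. That change produced no change at the digits printed from compound 1 to compound 2 (within the scatter). Compound 3 rests on a different core; how the core of compound 3 differs from the core of compound 1 is not broken down here. Against compound 1 and against compound 2, compound 3 carries the highest of the three numbers, and both gaps lie beyond the scatter.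

Compound 4, `CCCc1ccccc1NS(=O)(=O)c1cccc(NC(=O)NCCCCl)c1`, is not yet measured. It stands to compound 3 as compound 2 stands to compound 1: the change is methyl in place of hydrogen on a saturated chain carbon, two bonds along the chain from an aromatic carbon, the same change at the same kind of place, now made on the core of compound 3. For the measured compounds named here, the only precedent is the pair compound 1 and compound 2. Because that earlier step no change at the digits printed from compound 1 to compound 2 (within the scatter) lay within the scatter, the step expected here is no change at the digits printed from compound 3 to compound 4 (within the scatter). In this assay compound 4 is therefore estimated at 43000 nM, with the estimate spanning 20000 nM to 90000 nM.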

Compound 4, half-maximal inhibitory concentration: 18000 nM
For compound 4 the middle estimate is 2.4-fold (0.38 log units) above the measured one, outside the stated range (below it).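

In this assay, the change from 2-ethylphenyl to 2-propylphenyl on the core of compound 3 gives a 2.4-fold lower number from compound 3 to compound 4 (0.38 log units; beyond the scatter). Set beside the same change on the core of compound 1, this step cannot be told apart from the earlier one: the same change on two cores in this assay, no change at the digits printed (within the scatter) from compound 1 to compound 2 and a 2.4-fold lower number (0.38 log units; beyond the scatter) from compound 3 to compound 4, 2.4-fold (0.38 log units) apart, within the scatter of two such steps The two pairs therefore give no firm sign that the change behaves differently on the two cores, although only the newer step lies beyond the scatter; they also do not show that it behaves alike on both, and two pairs cannot establish a rule for other cores in the series.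

Still open, from the compounds shown here alone, is whether a longer chain such as butyl, or a branched one such as isopropyl, would extend or reverse the step on either core. Also open, going by these compounds, is what an amine or a carboxylic acid would do on the same saturated chain carbon, two bonds along the chain from an aromatic carbon.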